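The source may report more compounds than this note shows. Statements on the series, on what has been measured and on what is new or still open speak of the compounds shown alone.

For the measured compounds named here, in a functional assay on A-431 cells (Homo sapiens) for inhibition, read by MTT assay, with a stated time of 72 h (a higher number here means a weaker inhibitor, a lower number a stronger inhibitor), compound 3 `C=CC(=O)Nc1cccc(Oc2nc(Nc3cccc(C#N)c3)nc3ccsc23)c1` gives 3790 nM, the lowest of the three numbers measured so far. Compound 1 `C=CC(=O)Nc1cccc(Oc2nc(Nc3cccc(OC)c3)nc3ccsc23)c1` gives 4790 nM, and the step of a 1.3-fold lower number from compound 1 to compound 3 (0.10 log units; within the scatter) shows that these two lie within the scatter of each other. Compound 2 `CCC/C=C/C(=O)Nc1cccc(Oc2nc(Nc3cccc(OC)c3)nc3ccsc23)c1` gives 8090 nM, a number that stands beyond the scatter above compound 3. Compound 4 `CC/C=C/C(=O)Nc1cccc(Oc2nc(Nc3cccc(C#N)c3)nc3ccsc23)c1` has not yet been measured; it differs from compound 3 by but-1-en-1-yl in place of vinyl on a carbonyl carbon. Going by the values given here, the one measured step that bears on this is a 1.7-fold higher number from compound 1 to compound 2 (0.23 log units; within the scatter), where a longer chain likewise replaced vinyl on the carbonyl carbon. A similarly small move is therefore expected, and compound 4 is estimated at 5700 nM, with a range from 2500 nM to 13000 nM, which means an expected step of a 1.5-fold higher number from compound 3 to compound 4 (0.18 log units; within the scatter), probably within the scatter.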

Compound 4, half-maximal inhibitory concentration: 36200 nM
Compound 4: middle estimate off by 6.4-fold (0.80 log units), on the low side, outside the stated range (above it).
By their numbers in this assay, from the lowest: compounds 3, 1 and 2 (each within the scatter of the next, the first and the last beyond it); then compound 4.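

In this assay, but-1-en-1-yl in place of vinyl on a carbonyl carbon gives a 9.6-fold higher number from compound 3 to compound 4 (0.98 log units; beyond the scatter), so a change at this position can matter well beyond the scatter. The earlier step, a 1.7-fold higher number from compound 1 to compound 2 (0.23 log units; within the scatter), with pent-1-en-1-yl on the methoxy compounds, stayed within the scatter, so replacing vinyl here has no single size of effect across these pairs. No measurement shown explains why the two steps differ. Still open, from the compounds shown here alone, is whether the large step belongs to but-1-en-1-yl itself or to its pairing with cyano, and how an amine in place of vinyl would read.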